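The source may hold more compounds than are shown below. What is called first, only, known or untested is meant among the compounds shown, and "the series" means these compounds.

Measured so far:

compound 1 `NS(=O)(=O)c1ccc(COc2ccc(CNC(=O)[C@@H]3CCC(=O)N3Cc3ccc(C(F)(F)F)cc3)cc2)cc1` — > 5000 nM in an assay on HEK293 cells for inhibition of Ataxin-2 (Mus musculus), read by fluorescence and Amplex Red; a lower number here means a stronger inhibitor, a higher number a weaker inhibitor
compound 2 `O=C(O)c1ccc(COc2ccc(CN3CCC[C@H]3C(=O)NCc3ccccc3)cc2)cc1` — > 5000 nM

Compound 1 carries a primary sulfonamide on its outer ring and a trifluoromethylbenzyl on the lactam nitrogen; its value in this assay is a limit only, not a number. Compound 2 carries a carboxy in place of the sulfonamide and a pyrrolidine in place of the lactam; its value in this assay is likewise a limit only. Where compound 2 stands is therefore only bounded from one side, and the same holds for the other value shown (the limit of > 5000 nM in this assay, at which 2 of the 2 values shown sit), so no step between measured compounds can be sized and no direction of change in the series can be read.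

Compound 3 `O=C(NCc1ccccc1)[C@@H]1CCCN1Cc1ccc(OCc2ccc(-c3nn[nH]n3)cc2)cc1` is not yet measured. It differs from compound 2 by 2H-tetrazol-5-yl in place of carboxy on an aromatic carbon, para to a large group. With both neighbours sitting at the limit, the step from compound 2 to compound 3 is expected to be none beyond the scatter, a step that the limit leaves unreadable from compound 2 to compound 3. Compound 3 is expected to come out at 7000 nM, within 2500 nM to 20000 nM, most likely reported as a limit again.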

Compound 3, half-maximal inhibitory concentration: > 5000 nM
Compound 3: a limit, no number (the forecaster's own chance of this, stated with the estimate: 75%); the middle value is on the limit's open side.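

For the compounds shown here, compound 3, with 2H-tetrazol-5-yl in place of carboxy, gives only a limit in this assay, as compound 2 does, so no new step between these two compounds can be read: the limit of > 5000 nM in this assay, at which 3 of the 3 values shown sit. The compounds shown leave open how strongly any of them inhibits and whether exchanging the carboxy for 2H-tetrazol-5-yl changes that at all.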